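A few compounds are considered here, and "the series" means these few. Any claim that something is new, unique, unknown or untested is made for them only; others in the source may bear on it.

Of the compounds shown here, three have been measured in an assay for inhibition of histone-lysine N-methyltransferase, H3 lysine-79 specific (Homo sapiens), read by scintillation counting, with stated times of 15 min and 60 min, tested at 50 uM, in the presence of a further agent that is not named here; on this read-out higher numbers stand for a stronger effect at the one concentration tested and lower numbers for a weaker effect. Compound 1 `C(=C/c1nn2c(-c3ccncc3)nnc2s1)\c1ccco1` gives 67% in this assay. Compound 2 `COc1ccccc1-c1nnc2sc(/C=C/c3ccco3)nn12` gives 75%, a number lying within the usual scatter of the value for compound 1. Compound 3 `Cc1occc1-c1nnc2sc(CCc3ccccc3)nn12`, which carries a phenethyl chain rather than the furanylvinyl group, gives 11%, far below compound 1 and beyond the scatter. Compound 1 therefore stands as the second highest of the three numbers, close to compound 2 and well above compound 3.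

Compound 4 `Fc1cccc(-c2nnc3sc(/C=C/c4ccco4)nn23)c1` has not yet been measured in this assay. It differs from compound 1 in one place: 3-fluorophenyl in place of pyridin-4-yl on an aromatic carbon. Among the compounds with values here, no step between two measured compounds shows this exact change, so the expectation rests on compound 2, whose 75% shows that a carbon-only six-membered aromatic ring in this place is compatible with a value near that of compound 1. The step of a number 3 percentage points higher from compound 1 to compound 4 (within the scatter) is therefore expected to be small, without a clear direction beyond the scatter. Compound 4 is estimated at 70%, with a likely range from 52% to 86%.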

Compound 4, a percentage reported as inhibition, at one concentration (the size of the read-out at that concentration, not a potency): 22%
Compound 4: the middle estimate sits 48 percentage points above what was measured; the measured number lies below the stated range.
By their numbers in this assay, from the lowest: compound 3; then compound 4; then compounds 1 and 2 (each within the scatter of the next).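

In this assay, the change to 3-fluorophenyl in place of pyridin-4-yl gives a number 45 percentage points lower from compound 1 to compound 4 (beyond the scatter) and shows that this position, on an aromatic carbon between two ring nitrogen atoms, does not accept every six-membered aromatic ring of carbon only. With the methoxyphenyl ring in this place compound 2 gives 75% in this assay and with 3-fluorophenyl compound 4 gives 22% in the same assay, so a carbon-only ring here does not by itself settle the number. Nothing at hand gives a reason for this drop.

The compounds shown leave open whether an unsubstituted phenyl, a pyridin-3-yl or an aminophenyl group in this place would read like compound 1 or like compound 4. They also leave open whether the fluorine itself or its place on the ring separates compound 4 from compound 2.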